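Estimating clearance after a change to 2-fluorophenyl

The source may report more compounds than this note shows. Statements on the series, on what has been measured and on what is new or still open speak of the compounds shown alone.

Values in an in vitro ADME assay on microsomes from liver (Homo sapiens) for metabolic stability; on this read-out higher numbers stand for fast clearance and lower numbers for slow clearance:
- compound 1 `COc1ccc(C(=O)N2CCC(=CC(=O)N[C@@H]3CCN(Cc4ccc5cc(F)ccc5c4)C3)CC2)cc1`: 252 mL/min/kg
- compound 2 `Cc1ccc(C(=O)N2CCC(=CC(=O)N[C@@H]3CCN(Cc4ccc5cc(F)ccc5c4)C3)CC2)c(O)c1`: 156 mL/min/kg
- compound 3 `COc1ccc(C(=O)N2CCC(=CC(=O)N[C@@H]3CCN(Cc4ccc5cc(F)ccc5c4)C3)CC2)c(O)c1`: 232 mL/min/kg

These three compounds share one core and differ only in the aromatic group on a carbonyl carbon. Compound 3 at 232 mL/min/kg lies within the scatter of both other compounds.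

Compound 4 `O=C(C=C1CCN(C(=O)c2ccccc2F)CC1)N[C@@H]1CCN(Cc2ccc3cc(F)ccc3c2)C1` has not been measured yet. It differs from compound 3 in one place: 2-fluorophenyl in place of 2-hydroxy-4-methoxyphenyl on a carbonyl carbon. That is, 2-fluorophenyl in place of 2-hydroxy-4-methoxyphenyl on a carbonyl carbon.

Within the data shown here, three measured steps bear on this change, all at the same place. Adding hydroxy gave a 1.1-fold lower number from compound 1 to compound 3 (0.04 log units; within the scatter). Putting methoxy in place of methyl gave a 1.5-fold higher number from compound 2 to compound 3 (0.17 log units; within the scatter). Exchanging the whole group gave a 1.6-fold lower number from compound 1 to compound 2 (0.21 log units; within the scatter). None of them left the scatter. Among the measured compounds shown here, no measured compound carries the 2-fluorophenyl group, so the range stays wide.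

The expected change is no larger than the scatter, with an estimated 1.2-fold lower number from compound 3 to compound 4 (0.06 log units; within the scatter). Compound 4 is expected at 200 mL/min/kg, with an estimated range of 110 mL/min/kg to 340 mL/min/kg.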

Compound 4, clearance: 590 mL/min/kg
For compound 4 the middle estimate is 3.0-fold (0.47 log units) below the measured one; the measured number lies above the stated range.
By their numbers in this assay, from the lowest: compounds 2, 3 and 1 (each within the scatter of the next); then compound 4.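

In this assay, among these compounds, the aromatic group on this carbonyl carbon now makes a difference beyond the scatter, which no step among the earlier compounds did: the change to 2-fluorophenyl gives a 2.5-fold higher number from compound 3 to compound 4 (0.41 log units; beyond the scatter) and, measured against the other two groups, a 3.8-fold higher number from compound 2 to compound 4 (0.58 log units; beyond the scatter) as well as a 2.3-fold higher number from compound 1 to compound 4 (0.37 log units; beyond the scatter). Compound 4 thus stands apart from all three earlier compounds, each of which carries a hydroxy or methoxy group on its aromatic ring, while the 2-fluorophenyl group carries neither. Nothing measured here explains this rise.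

The compounds shown leave open whether the higher number goes with the fluorine itself or with the loss of the hydroxy and methoxy groups. A plain phenyl or a 2-aminophenyl group at this place would bear on that question.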